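A few compounds are considered here, and "the series" means these few. Any claim that something is new, unique, unknown or untested is made for them only; others in the source may bear on it.

Compound 1 `COc1ccc(-c2cc(/C=C/C(=O)c3cc(OC)c(OC)c(OC)c3)nc3cc(-c4ccccc4)nn23)cc1OC` gives 8300 nM in a functional assay on DU-145 cells (Homo sapiens) for antiproliferative activity, read by MTT assay, with a stated time of 24 h; a lower number here means a stronger inhibitor, a higher number a weaker inhibitor. Compound 2 `COc1ccc(/C=C/C(=O)c2cc(-c3cc(OC)c(OC)c(OC)c3)n3nc(-c4ccccc4)cc3n2)cc1OC` gives 15300 nM in this assay, and compound 3 `COc1ccc(-c2cc(/C=C/C(=O)c3ccccc3)nc3cc(-c4ccccc4)nn23)cc1` gives 13700 nM; both numbers lie within the scatter of the number for compound 1, so the three compounds cannot be ranked against one another on these data. Compound 4 `COc1ccc(-c2cc(/C=C/C(=O)c3ccc(C)cc3)nc3cc(-c4ccccc4)nn23)cc1OC` has not yet been measured in this assay. It differs from compound 1 in one place: 4-methylphenyl in place of 3,4,5-trimethoxyphenyl on a carbonyl carbon. Among the measured compounds shown here, no step between two measured compounds isolates this change, so the expectation rests on the spread of the three numbers. The step is expected to be small, a 1.4-fold higher number from compound 1 to compound 4 (0.16 log units; within the scatter), and not beyond the scatter. For compound 4 the estimated value in this assay is 12000 nM, with a range of 5000 nM to 30000 nM.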

Compound 4, half-maximal inhibitory concentration: 26800 nM
The estimate for compound 4 lay 2.2-fold (0.35 log units) below the measured number; the range from low to high includes it.
By their numbers in this assay, from the lowest: compounds 1, 3, 2 and 4 (each within the scatter of the next, the first and the last beyond it).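

In this assay, among the compounds shown here, the change on the carbonyl carbon from 3,4,5-trimethoxyphenyl to 4-methylphenyl gives a 3.2-fold higher number from compound 1 to compound 4 (0.51 log units; beyond the scatter) and is the only readable step so far. This position is therefore sensitive to the group it carries, even though one six-membered aromatic ring of carbon only remains; the leaving group has 3 hydrogen-bond acceptors and the entering group 0. No measurement shown accounts for the step. From the compounds shown here alone, it remains open whether losing the methoxy groups or gaining the methyl matters more. A single methoxy group, an amine or a carboxylic acid on that ring would test this.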